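Removing the Fluoro from a Cyanoxime Amide

The source may hold more compounds than are shown below. What is called first, only, known or untested is meant among the compounds shown, and "the series" means these compounds.

Going by the values given here, compound 1 `N#C/C(=N\O)C(=O)Nc1cccc(F)c1` stands highest of the two numbers so far in a physicochemical assay for acid dissociation, using potentiometric titration, where compound 1 gives 4.92. Its nearest neighbour, compound 2 `N#C/C(=N\O)C(=O)Nc1cc(F)cc(F)c1`, gives 4.81; the step of a number 0.11 log units lower from compound 1 to compound 2 (within the scatter) is within the scatter. Compound 3 `N#C/C(=N\O)C(=O)Nc1ccccc1` differs from compound 1 by hydrogen in place of fluoro on an aromatic carbon. Among the compounds with values here, the only measured step that bears on this change, a number 0.11 log units lower from compound 1 to compound 2 (within the scatter), ran the opposite way and was within the scatter, so no step beyond the scatter in this assay is expected, at most a slight rise. Compound 3 is therefore estimated at 5.03, between 4.75 and 5.35, an expected step of a number 0.11 log units higher from compound 1 to compound 3 (within the scatter).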

Compound 3, acid dissociation constant: 5.12
The estimate for compound 3 lay 0.09 log units below the measured number, within the range that was stated.
By their numbers in this assay, from the lowest: compounds 2, 1 and 3 (each within the scatter of the next, the first and the last beyond it).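

In this assay, hydrogen in place of fluoro on this aromatic carbon gives a number 0.20 log units higher from compound 1 to compound 3 (within the scatter) and so does not carry the number beyond the scatter. Going by these compounds alone, the earlier step concerned a second fluoro, whereas this one concerns the only fluoro of compound 1, which shows that this position tolerates the loss of that atom with the two numbers still within the scatter of each other. Nothing measured here accounts for the size of this step. On these data alone, whether a chloro, a methoxy or an amine on this same carbon would give a step beyond the scatter remains open. So does the effect of a carboxylic acid there.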